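A few compounds are considered here, and "the series" means these few. Any claim that something is new, unique, unknown or untested is made for them only; others in the source may bear on it.

Measured compounds:
compound 1 `O[C@@H]1[C@@H](OCc2ccccc2)[C@H](OCc2ccccc2)[C@@H](COCc2ccccc2)O[C@H]1CC1CCCCC1` — 4100 nM
compound 2 `CC(=O)O[C@@H]1[C@@H](OCc2ccccc2)[C@H](OCc2ccccc2)[C@@H](COCc2ccccc2)O[C@@H]1Cc1ccccc1` — "not active" (no number reported)
compound 3 `CC(=O)O[C@@H]1[C@@H](OCc2ccccc2)[C@H](OCc2ccccc2)[C@@H](COCc2ccccc2)O[C@H]1Cc1ccccc1` — "not active" (no number reported)

In a functional assay on HL-60 cells (Homo sapiens) for antiproliferative activity, read by MTT assay (a lower number here means a stronger inhibitor, a higher number a weaker inhibitor), compound 1 gives 4100 nM. Within the data shown here, that is the only number in this set: compound 2 is reported in this assay as "not active" (no number reported), and compound 3 is reported in this assay as "not active" (no number reported), so neither carries a figure that could be set against compound 1. Compounds 2 and 3 are a close pair, given (the fact that compounds 2 and 3 differ only in the configuration as drawn), and both end up without a reported number. Among the measured compounds shown here, no step between two measured compounds with a single change in one place is available, so nothing here sets a scale for how much a change at one position moves the read-out.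

Compound 4 `C=C[C@@H]1O[C@H](COCc2ccccc2)[C@@H](OCc2ccccc2)[C@H](OCc2ccccc2)[C@H]1O` is the next compound to be tested. It differs from compound 1 in one place: vinyl in place of cyclohexylmethyl on a saturated ring carbon. For the measured compounds named here, with compound 1 already a weak inhibitor and no measured step to lean on, the expectation is a modest loss rather than a gain, and a step of a 2.0-fold higher number from compound 1 to compound 4 (0.29 log units; within the scatter) from compound 1 to compound 4 is estimated. Compound 4 is expected to give 8000 nM in this assay, within a range of 2500 nM to 25000 nM.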

Compound 4, half-maximal inhibitory concentration: 11800 nM
For compound 4 the middle estimate is 1.5-fold (0.17 log units) below the measured one; the range from low to high includes it.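

In this assay, among these compounds, putting vinyl in place of cyclohexylmethyl on the saturated ring carbon next to the ring oxygen gives a 2.9-fold higher number from compound 1 to compound 4 (0.46 log units; beyond the scatter), the first measured step in this set and so the first scale for a change at this position. The step is modest, and compound 4 still has a measured value, so in this series, activity at this position does not depend on keeping the cyclohexylmethyl group, though that group does give the lower number of the two. The one available piece of supporting information concerns a different pair of compounds and offers no explanation for this step.

This single swap changes the group's size and removes its ring at the same time, so the result cannot show which of the two matters, and a longer straight chain such as hexyl, or a chain ending in an amine, at this carbon would be needed to separate them. Among the compounds shown here, compounds 2 and 3 have no reported number, so no steps to them can be read, and the role of the neighbouring hydroxy group remains open.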